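The compounds below may be only part of what the source reports. "The series", "measured", "known", "first", "only" and "open" are said of these compounds alone.

Measured compounds:

Compound 1, `COc1ccccc1C1CCN(c2ccn3c(CC4CC4)nnc3c2Cl)CC1`, gives 345%.
Compound 2, `COc1ccc(F)cc1C1CCN(c2ccn3c(CC4CC4)nnc3c2Cl)CC1`, gives 283%.
Compound 3, `COc1c(F)cccc1C1CCN(c2ccn3c(CC4CC4)nnc3c2C(F)(F)F)CC1`, gives 528%.

All three numbers come from a functional assay on CHO cells for agonist activity at metabotropic glutamate receptor 2 (Homo sapiens), read by scintillation counting and GTPgammaS binding, with a stated time of 30 min; on this read-out lower numbers stand for smaller maximal responses and higher numbers for larger maximal responses. Compound 1 and compound 2 share one core and differ in a single spot: fluoro in place of hydrogen on an aromatic carbon. That fluoro in place of hydrogen on an aromatic carbon came with a number 62 percentage points lower from compound 1 to compound 2 (beyond the scatter), so in this case adding the fluorine lowered the maximal response. Compound 3 has a different core; the difference between the two cores is not broken down here. In this assay compound 3 gives the highest of the three numbers, standing well beyond the scatter above both compound 1 and compound 2.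

Compound 4, `COc1c(F)ccc(F)c1C1CCN(c2ccn3c(CC4CC4)nnc3c2C(F)(F)F)CC1`, has not yet been measured. It is built from compound 3 by the same kind of change: fluoro in place of hydrogen on an aromatic carbon. The surroundings differ, though. In the measured pair the new fluorine sits meta to a large group and para to a methoxy group; in compound 4 it sits ortho to a large group, meta to a methoxy group and para to a fluoro group. Within the data shown here, because the only measured example of this change, a number 62 percentage points lower from compound 1 to compound 2 (beyond the scatter), lowered the response, a drop is expected here too, but a smaller certainty is attached to it since the place is not the same. The expected step is a number 68 percentage points lower from compound 3 to compound 4 (beyond the scatter). For compound 4 the estimate in this assay is 460%, within 340% to 600%.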

Compound 4, largest response reached (Emax), in percent of the reference or control that the assay uses: 421%
Beside the measured number, compound 4's estimate is 39 percentage points above it; measured number inside the range.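

In this assay, the added fluoro group again goes with a smaller maximal response, this time a number 107 percentage points lower from compound 3 to compound 4 (beyond the scatter). Going by these compounds, the direction of the step therefore carries over from one core to the other in these two pairs, but its size does not: the same change on two cores in this assay, a number 62 percentage points lower (beyond the scatter) from compound 1 to compound 2 and a number 107 percentage points lower (beyond the scatter) from compound 3 to compound 4, 45 percentage points apart, beyond the scatter of two such steps What sets the two sizes apart remains unknown: the cores differ, the new fluorine sits in a different place in each pair (ortho to a large group only in compound 4), and two pairs are too few to make a rule for the whole series.

The compounds shown leave open whether a different small group on the same aromatic carbon, such as a methyl group or a nitrile, would lower the response as the fluoro group does. They also leave open what a fluoro group would do at the place it takes in compound 4 if it were put on the core of compound 1, a comparison that would help separate the influence of the position on the ring from the influence of the core.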